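The compounds below may be only part of what the source reports. "The series", "measured", "known", "first", "only" and "open" are said of these compounds alone.

Measured compounds:
Compound 1 `COc1cc(Cl)cc(-c2nn(-c3cccc(NC(=O)Nc4ccc(Cl)c(C(F)(F)F)c4)c3)cc2-c2ccncc2)c1` — in a functional assay on HCC 2998 cells (Homo sapiens) for inhibition, read by sulforhodamine B assay, with a stated time of 48 h, tested at 0.1 uM (on this read-out lower numbers stand for a stronger effect and higher numbers for a weaker effect at the one concentration tested), compound 1 gives 94%.
Compound 2 `COc1cc(Cl)cc(-c2nn(-c3cccc(NC(=O)Nc4ccc(Cl)c(Cl)c4)c3)cc2-c2ccncc2)c1` — in this assay compound 2 gives 96%.
Compound 3 `COc1cc(Cl)cc(-c2nn(-c3cccc(NC(=O)Nc4cccc(C(F)(F)F)c4)c3)cc2-c2ccncc2)c1` — in this assay compound 3 gives 98%.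

Compound 3 stands highest of the three numbers, but only by small margins: the step of a number 2 percentage points higher from compound 2 to compound 3 (within the scatter) and the step of a number 4 percentage points higher from compound 1 to compound 3 (within the scatter) both lie within the scatter, as does the step of a number 2 percentage points higher from compound 1 to compound 2 (within the scatter). On these numbers the three compounds cannot be told apart, and none of them shows more than a slight effect at the concentration tested.

Compound 4 `COc1cc(Cl)cc(-c2nn(-c3cccc(NC(=O)c4cccc(C(F)(F)F)c4)c3)cc2-c2ccncc2)c1` differs from compound 3 in one place: 3-(trifluoromethyl)phenyl in place of (3-(trifluoromethyl)phenyl)amino on a carbonyl carbon. Among the measured compounds shown here, none of the measured steps touches this part of the molecule. They concern exchanges of chloro, trifluoromethyl and hydrogen on an aromatic carbon, and the exchange of 3-(trifluoromethyl)phenyl for 3,4-dichlorophenyl on an amide-type nitrogen, and each of them was within the scatter. For the measured compounds named here, the data thus give no direct guidance for this change, only a background in which every variation so far left the read-out essentially unmoved. The expected step is therefore none beyond the scatter, a number 3 percentage points lower from compound 3 to compound 4 (within the scatter). Compound 4 is estimated at 95% in this assay, with a range from 85% to 105%.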

Compound 4, a percentage reported as activity, at one concentration (the size of the read-out at that concentration, not a potency): 104%
Beside the measured number, compound 4's estimate is 9 percentage points below it; the measured number falls inside the stated range.
By their numbers in this assay, from the lowest: compounds 1, 2, 3 and 4 (each within the scatter of the next).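

Among the compounds shown here, compound 4 is the first compound here in which the link itself changes, rather than a group on an aromatic carbon: (3-(trifluoromethyl)phenyl)amino gives way to 3-(trifluoromethyl)phenyl on the carbonyl carbon, which removes one nitrogen and its hydrogen-bond donor, and in this assay the result is a number 6 percentage points higher from compound 3 to compound 4 (within the scatter). The two wider comparisons read the same way, with a number 8 percentage points higher from compound 2 to compound 4 (within the scatter) and a number 10 percentage points higher from compound 1 to compound 4 (within the scatter), although each of these also changes the groups on the aromatic ring, so in these compounds the amino nitrogen on this carbonyl carbon can be removed without the read-out leaving the scatter. No measurement at hand explains this result.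

All four compounds show little effect at the one concentration tested, which leaves open whether this nitrogen matters in a compound with a clear effect in this assay. Also open, from the compounds shown here alone, is what a sulfonamide or a methylene chain at this place would do, or an amine or a carboxylic acid in place of the trifluoromethyl group.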